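The source may hold more compounds than are shown below. What is called first, only, known or untested is meant among the compounds shown, and "the series" means these compounds.

Measured compounds:
compound 1, `Cc1nc(N)sc1CCCN/C(N)=N/C(=O)NC(C)c1cccc(F)c1`, with 0.85;
compound 2, `CCCCCNC(=O)/N=C(\N)NCCCc1sc(N)nc1C`, with 0.78.

In a functional assay on Right cardiac atrium for agonist activity at histamine H2 receptor (Cavia porcellus), with a stated time of 30 min, in the presence of a further agent that is not named here (on this read-out higher numbers stand for larger maximal responses and lower numbers for smaller maximal responses), compound 1 gives 0.85, the higher of the two numbers obtained so far. The nearest of them belongs to compound 2, which in this assay gives 0.78; the gap between these two values lies within the usual scatter, so the two compounds cannot be ranked against each other on this read-out. Among the measured compounds shown here, no step between measured compounds differing in a single place is available, so there is no measured guide for the size of a change at the aryl group.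

Compound 3, `Cc1nc(N)sc1CCCN/C(N)=N/C(=O)NC(C)c1ccc(Br)cc1`, has not yet been measured in this assay. It differs from compound 1 in one place: 4-bromophenyl in place of 3-fluorophenyl on a saturated chain carbon bound to an amide-type nitrogen and a saturated chain carbon. Since both measured compounds, with different groups on the amide-type nitrogen, reach maximal responses close to one another, the step a number 0.030 lower from compound 1 to compound 3 (within the scatter) is expected to stay within the scatter, with no direction beyond it. For compound 3 an intrinsic activity of 0.82 is estimated, within a range from 0.62 to 0.97.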

Compound 3, intrinsic activity: the largest response reached, as a fraction of the reference agonist's: 0.87
For compound 3 the middle estimate is 0.050 below the measured one; measured number inside the range.
By their numbers in this assay, from the lowest: compounds 2, 1 and 3 (each within the scatter of the next).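

At this position, exchanging 3-fluorophenyl for 4-bromophenyl now has a measured size in this assay: a number 0.020 higher from compound 1 to compound 3 (within the scatter). Among the compounds shown here, this is the first step between compounds that differ in one place, and it shows that these two aryl groups, on a saturated chain carbon bound to an amide-type nitrogen and a saturated chain carbon, cannot be told apart on the maximal response. No measurement is at hand that could account for this result.

The exchange alters the halogen and its place on the ring together, so the compounds shown do not separate one from the other, and they give no step for either alone. Going by these compounds, it also remains open whether an unsubstituted phenyl, a methoxyphenyl or a pyridyl group at the same position, or a hydroxyl or an amine on the ring, would stay within the scatter of compound 1 or move the response beyond it.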